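The compounds below may be only part of what the source reports. "The series", "measured", "known", "first", "only" and "open" are said of these compounds alone.

Of the compounds shown here, three have been measured in an assay on HL-60 cells for inhibition of glutathione S-transferase P (Homo sapiens), read by spectrophotometry, tested at 5 uM; a lower number here means less inhibition, a higher number more inhibition at the concentration tested (going by the name of the read-out). Compound 1 `C=C(CC)C(=O)c1ccc(OCc2nc(-c3ccc4ccccc4c3)cs2)c(C)c1C` gives 0% in this assay, and compound 2 `C=C(CC)C(=O)c1ccc(OCc2nc(-c3ccc(C(F)(F)F)cc3)cs2)c(C)c1C` gives 0%. Compound 3 `C=C(CC)C(=O)c1ccc(OCc2nc(-c3ccc4ccccc4c3)cs2)cc1Cl` gives 9.5% in this assay; its number and that of compound 1 sit within the scatter of each other, as do its number and that of compound 2. The difference between the core of compound 1 and the core of compound 3 is not broken down here.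

Compound 2 differs from compound 1 by a single change, (4-(trifluoromethyl)phenyl in place of naphthalen-2-yl on an aromatic carbon), and that change made the step of no change at the digits printed from compound 1 to compound 2 (within the scatter). Compound 4 `C=C(CC)C(=O)c1ccc(OCc2nc(-c3ccc(C(F)(F)F)cc3)cs2)cc1Cl` carries the same change relative to compound 3, namely (4-(trifluoromethyl)phenyl in place of naphthalen-2-yl on an aromatic carbon), and has not yet been measured in this assay.

Because the earlier step of no change at the digits printed from compound 1 to compound 2 (within the scatter), the corresponding step expected here is a number 3.5 percentage points lower from compound 3 to compound 4 (within the scatter). On this basis compound 4 is estimated to give 6% in this assay, with the expected range running from 0% to 16%.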

Compound 4, a percentage reported as inhibition, at one concentration (the size of the read-out at that concentration, not a potency): 19.7%
The estimate for compound 4 lay 13.7 percentage points below the measured number; measured number outside the range, above it.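

In this assay, 4-(trifluoromethyl)phenyl in place of naphthalen-2-yl gave a number 10.2 percentage points higher from compound 3 to compound 4 (beyond the scatter). Set beside the same change on the other core, this new step cannot be told apart from the earlier one: the same change on two cores in this assay, no change at the digits printed (within the scatter) from compound 1 to compound 2 and a number 10.2 percentage points higher (beyond the scatter) from compound 3 to compound 4, 10.2 percentage points apart, within the scatter of two such steps. This means that the series shows no firm sign that the core alters what the change does, but it does not prove that the change carries over unaltered, as it rests on just two cores and on readings taken at one concentration, which are not potencies.

The compounds shown carry only these two aromatic groups at this place on the ring with nitrogen and sulfur, so what an amine or a carboxylic acid there would give remains open. Also open, as far as these compounds go, is whether the same change would give a similar step on a third core, or at other test concentrations.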